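The source may report more compounds than this note shows. Statements on the series, on what has been measured and on what is new or still open speak of the compounds shown alone.

Working notes on the quinolinyloxy-triazine series. All members share a core carrying a (quinolin-4-yl)oxy group and a nitrile- and trifluoromethyl-bearing anilino group, varied only at the remaining ring carbon. Among the measured compounds shown here, in a functional assay on DU-145 cells (Homo sapiens) for cytotoxicity, read by sulforhodamine B assay, with a stated time of 48 h (a lower number here means a stronger inhibitor of growth, a higher number a weaker inhibitor of growth), compound 2 `CC1CC(C)CN(c2nc(Nc3ccc(C#N)c(C(F)(F)F)c3)nc(Oc3ccnc4ccccc34)n2)C1` gives 68000 nM, the only numerical value in the set. Compound 1 `N#Cc1ccc(Nc2nc(Oc3ccnc4ccccc34)nc(N3CCN(C(c4ccccc4)c4ccc(Cl)cc4)CC3)n2)cc1C(F)(F)F` is reported only as the limit > 100000 nM. Compound 3 `N#Cc1ccc(Nc2nc(Oc3ccnc4ccccc34)nc(N3CCC(Cc4ccccc4)CC3)n2)cc1C(F)(F)F` is likewise reported only as the limit > 100000 nM. For the measured compounds named here, two of three members thus sit at the limit of > 100000 nM in this assay, at which 2 of the 3 values shown sit, so compound 2 stands as the sole quantified point, and no step between measured compounds exists.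

Compound 4 `N#Cc1ccc(Nc2nc(Oc3ccnc4ccccc34)nc(N3CCN(c4ccccn4)CC3)n2)cc1C(F)(F)F` carries 4-(pyridin-2-yl)piperazin-1-yl in place of 3,5-dimethylpiperidin-1-yl on an aromatic carbon. The new substituent is the piperazine type seen in compound 1, which stands at the limit > 100000 nM. The step from compound 2 to compound 4 is therefore expected as a 1.5-fold higher number from compound 2 to compound 4 (0.17 log units; within the scatter), toward weaker growth inhibition, with a substantial chance that only a limit is reported. Compound 4 is expected near 100000 nM, within 40000 nM to 300000 nM.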

Compound 4, concentration for total growth inhibition: > 100000 nM
Compound 4 was reported as a limit; the forecaster's own chance of this, stated with the estimate: 60%; the middle value lies on the limit itself.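

Among the compounds shown here, replacing 3,5-dimethylpiperidin-1-yl with 4-(pyridin-2-yl)piperazin-1-yl on the aromatic carbon gives the first readable step at this position in this assay: an at least 1.4-fold higher number from compound 2 to compound 4 (0.16 log units; that floor lies within the scatter). Going by these compounds, that step is only a floor, so it establishes no loss of growth inhibition beyond the scatter, and its true size remains unknown. Compound 4 now shares the limit with compound 1, also a piperazine, and with compound 3, a piperidine, so ring type does not separate the limit compounds from compound 2: the limit of > 100000 nM in this assay, at which 3 of the 4 values shown sit.

Compounds 1, 3 and 4 cannot be ordered against one another. On these data alone, it remains open whether a morpholine, an unsubstituted piperazine or an open-chain dialkylamine at this position would give a value under the limit in this assay.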